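The compounds below may be only part of what the source reports. "The series", "measured", "known", "first", "only" and "open" are said of these compounds alone.

Compound 1 `CC(C)(C)c1cc(NC(=O)c2ccc(Cl)cc2Cl)ccc1O`: > 1 h
Compound 2 `CC(C)c1cc(NC(=O)c2ccc(Cl)cc2Cl)ccc1O`: > 1 h
Compound 3 `CCc1cc(NC(=O)c2ccc(Cl)cc2Cl)ccc1O`: > 1 h

All three compounds were tested in an ADME assay on a cell-free system (serum) for metabolic stability (on this read-out lower numbers stand for a shorter-lived compound and higher numbers for a longer-lived compound), and none of them gave an exact number. Compound 3 is known only by a limit, > 1 h. It shares this position with the rest of the series: the limit of > 1 h in this assay, at which 3 of the 3 values shown sit.

Compound 4 `Cc1cc(NC(=O)c2ccc(Cl)cc2Cl)ccc1O` differs from compound 3 in one place: hydrogen in place of methyl on a saturated chain carbon bound to an aromatic carbon. Ethyl becomes methyl, with hydrogen in place of methyl on a saturated chain carbon bound to an aromatic carbon.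

The closest measured precedent is a step that the two limits leave unreadable from compound 2 to compound 3, where hydrogen also takes the place of methyl. The other two measured changes, a step that the two limits leave unreadable from compound 1 to compound 2 and a step that the two limits leave unreadable from compound 1 to compound 3, give no size either. With no size to carry over, no step beyond the scatter is expected in this assay. The expected change is a step that the limit leaves unreadable from compound 3 to compound 4. For compound 4 the estimated half-life is 2 h, with an expected range of 1 h to 6 h.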

Compound 4, half-life: > 1 h
Compound 4: no number, only a limit; the forecaster's own chance of this, stated with the estimate: 85%; the middle value does not contradict the limit.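

No new step can be read for compound 4 against compound 1, compound 2 or compound 3, as all four stand at one limit: the limit of > 1 h in this assay, at which 4 of the 4 values shown sit. The compounds shown leave open the actual half-life of each in this assay and whether going from tert-butyl to methyl changes it at all.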